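This account rests on a few compounds, and the source may have more. Where it says the series, first, only, none or still open, it means among the compounds named here.

Compound 1 `Cc1ncn2c(NCc3ccco3)nncc12` gives > 48000 nM in a functional assay for inhibition, with Homo sapiens as the target (on this read-out lower numbers stand for stronger inhibition and higher numbers for weaker inhibition), which is a limit of the assay.
Compound 2 `c1coc(CNc2nncc3cncn23)c1` gives > 48000 nM, also a limit.
Compound 3 `CCCc1ncc2c(C)nnc(SC)n12` gives > 48000 nM, again a limit.

All three values sit at the limit of > 48000 nM in this assay, at which 3 of the 3 values shown sit. The change from compound 1 to compound 2, (hydrogen in place of methyl on an aromatic carbon), produces a step that the two limits leave unreadable from compound 1 to compound 2. Compound 4 `CCCc1ncc2cnnc(SC)n12` has not been measured; it differs from compound 3 by hydrogen in place of methyl on an aromatic carbon, the same kind of change, though the surroundings differ: in compound 3 the site is on a six-membered aromatic ring with 3 nitrogen, ortho to a fused ring and para to a methylsulfanyl group, whereas in compound 1 it is on a five-membered aromatic ring with 2 nitrogen. The difference between the two cores is not broken down here. Given that compound 1 and compound 2 both remain at the limit, the step from compound 3 to compound 4 is expected to be a step that the limit leaves unreadable from compound 3 to compound 4. Compound 4 is therefore expected to give 70000 nM in this assay, within 25000 nM to 200000 nM, most probably reported only as a limit.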

Compound 4, half-maximal inhibitory concentration: > 48000 nM
Compound 4 gave a limit, no number; the forecaster's own chance of this, stated with the estimate: 85%; the middle value does not contradict the limit.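

No step can be read from compound 3 to compound 4 in this assay, and both values are limits: the limit of > 48000 nM in this assay, at which 4 of the 4 values shown sit.

The compounds shown leave open whether hydrogen in place of methyl changes inhibition at all: none gives a number.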